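The compounds below may be only part of what the source reports. "The series", "measured", "known", "first", "only" and "open" are said of these compounds alone.

Measured in a functional assay on BaF3 cells (Mus musculus) for inhibition, read by CCK-8 assay, with a stated time of 72 h; a lower number here means a stronger inhibitor of growth, a higher number a weaker inhibitor of growth:
- compound 1 `Cc1ccc(NC(=O)Nc2ccc(Oc3cc(NCc4ccccc4)ncn3)cc2)cc1C(F)(F)F`: 3010 nM
- compound 2 `Cc1ccc(NC(=O)Nc2ccc(Oc3cc(/N=C/N(C)C)ncn3)cc2)cc1C(F)(F)F`: 6610 nM
- compound 3 `CC(=O)Nc1cc(Oc2ccc(NC(=O)Nc3cc(-n4cnc(C)c4)cc(C(F)(F)F)c3)cc2)ncn1`: 1320 nM

Compound 2, at 6610 nM, has the highest of the three numbers, which makes it the weakest inhibitor of growth here. Compound 4 `COCCNc1cc(Oc2ccc(NC(=O)Nc3ccc(C)c(C(F)(F)F)c3)cc2)ncn1` keeps its core and exchanges one group: a group of 5 heavy atoms (3 carbon, 1 nitrogen, 1 oxygen; no ring) in place of a group of 5 heavy atoms (3 carbon, 2 nitrogen; no ring), on an aromatic carbon. The entering group is (2-methoxyethyl)amino. Among the measured compounds shown here, only one measured step changes this same place, a 2.2-fold higher number from compound 1 to compound 2 (0.34 log units; beyond the scatter), and it is modest. Compound 3 differs from compound 2 in more than one place, so it is a weaker guide. A similarly modest move towards a lower number is therefore expected, and the expected step is a 1.9-fold lower number from compound 2 to compound 4 (0.28 log units; within the scatter). For compound 4 the estimate is 3500 nM, with an expected range of 1200 nM to 9000 nM.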

Compound 4, concentration for 50% growth inhibition: 7950 nM
Estimate against measurement, compound 4: 2.3-fold (0.36 log units) below; measured number inside the range.
By their numbers in this assay, from the lowest: compound 3; then compound 1; then compounds 2 and 4 (each within the scatter of the next).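

The exchange in compound 4 does not move the number outside the scatter (a 1.2-fold higher number from compound 2 to compound 4 (0.08 log units; within the scatter)), so (2-methoxyethyl)amino and the group it replaces cannot be told apart at this position. The ring on the chain does register, though: with the nitrogen on the aromatic carbon kept, methoxymethyl in place of phenyl gives a 2.6-fold higher number from compound 1 to compound 4 (0.42 log units; beyond the scatter). No measurement here explains either result.

The compounds shown leave open whether a longer chain on that nitrogen, or a chain ending in a carboxylic acid, would lower the number. They also leave open whether a substituted phenyl would.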